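Replacing chloro with propylamino on a shared core

A few compounds are considered here, and "the series" means these few. Any claim that something is new, unique, unknown or untested is made for them only; others in the source may bear on it.

Measured so far:
Compound 1, `CCOc1ncnc2c1ncn2C[C@@H]1C[C@H](CO)c2ccccc21`: 24 ug/mL
Compound 2, `OC[C@H]1C[C@@H](Cn2cnc3c(Cl)ncnc32)c2ccccc21`: 24 ug/mL

In a functional assay on CCRF-CEM cells (Homo sapiens) (on this read-out higher numbers stand for weaker inhibition and lower numbers for stronger inhibition), compound 1 gives 24 ug/mL and compound 2 gives 24 ug/mL, so compound 2 stands level with compound 1. For the measured compounds named here, the single step known here, no change at the digits printed from compound 1 to compound 2 (within the scatter), came with chloro in place of ethoxy on an aromatic carbon; it shows that swapping the group at this carbon left the read-out where it was.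

Compound 3, `CCCNc1ncnc2c1ncn2C[C@@H]1C[C@H](CO)c2ccccc21`, carries the change (propylamino in place of chloro on an aromatic carbon). Going by the values given here, no measured step involves propylamino, so the only guide is the unchanged step between compound 1 and compound 2, which bears on the same carbon but a different group. On that basis the step of no change at the digits printed from compound 2 to compound 3 (within the scatter) is expected to be small, with no clear direction beyond the scatter. Compound 3 is therefore estimated at 24 ug/mL, within a range from 8 ug/mL to 70 ug/mL.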

Compound 3, half-maximal inhibitory concentration: 24 ug/mL
Compound 3: middle estimate and measured number agree at the digits printed, within the range that was stated.
By their numbers in this assay, from the lowest: compounds 1, 2 and 3 (each within the scatter of the next).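

In this assay, propylamino in place of chloro on this aromatic carbon brought no change at the digits printed from compound 2 to compound 3 (within the scatter), and propylamino in place of ethoxy brought no change at the digits printed from compound 1 to compound 3 (within the scatter). Three different groups at this carbon, including propylamino, the only one of the three that carries a hydrogen-bond donor, therefore give the same read-out, so among these compounds, the identity of the group at this carbon makes no visible difference. Nothing available here bears on what lies behind this unchanged read-out.

The compounds shown leave open whether a carboxylic acid, a longer chain such as octylamino, or a phenyl ring on this carbon would shift the read-out. They also leave open whether replacing the hydroxymethyl group elsewhere on the shared core with an amine would change it.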